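Working notes: compound 3 to compound 4

A few compounds are considered here, and "the series" means these few. Any claim that something is new, unique, unknown or untested is made for them only; others in the source may bear on it.

Compound 1 `CC(C(=O)O)c1nn(Cc2cn3cc(OCC4CC4)c(Cl)cc3n2)c2ccccc2c1=O` gives 35 mL/min/kg
Compound 2 `O=C(O)C1(c2nn(Cc3cn4cc(OCC5CC5)c(Cl)cc4n3)c3ccccc3c2=O)CC1` gives < 15 mL/min/kg (a limit)
Compound 3 `CC(C)(C(=O)O)c1nn(Cc2cn3cc(OCC4CC4)c(Cl)cc3n2)c2ccccc2c1=O` gives 21.7 mL/min/kg

All three values come from an ADME assay on microsomes from liver (Homo sapiens) for metabolic stability; a lower number here means slower removal, a higher number faster removal of the compound. Only compound 1 and compound 3 give true numbers, and they sit close together: a 1.6-fold lower number from compound 1 to compound 3 (0.21 log units; within the scatter) is the gap between them. Compound 2 reports only a limit (< 15 mL/min/kg).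

Compound 4 `C[C@H](C(=O)O)c1nn(Cc2cn3cc(OCC4CC4)c(Cl)cc3n2)c2ccccc2c1=O` has 1-carboxyethyl in place of 1-carboxy-1-methylethyl on an aromatic carbon. Compound 1 carries the same 1-carboxyethyl without a defined stereocentre, so the most relevant measured step is a 1.6-fold lower number from compound 1 to compound 3 (0.21 log units; within the scatter), read in reverse. The other two steps, an at least 2.3-fold lower number from compound 1 to compound 2 (0.36 log units; beyond the scatter) and an at least 1.4-fold higher number from compound 2 to compound 3 (0.16 log units; that floor lies within the scatter), involve the 1-carboxycyclopropyl of compound 2 and bear on this change only indirectly. No measurement here shows what the defined stereocentre contributes, so the range is kept wide.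

In this assay no change beyond the scatter is expected, and the estimated step is a 1.5-fold higher number from compound 3 to compound 4 (0.17 log units; within the scatter). The value expected for compound 4 is 32 mL/min/kg, with an estimated range from 17 mL/min/kg to 60 mL/min/kg.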

Compound 4, clearance: < 15 mL/min/kg
Compound 4 was reported as a limit; the forecaster's own chance of this, stated with the estimate: 7%; middle value at least 2.1-fold (0.32 log units) from the limit.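

In this assay compound 4 gives < 15 mL/min/kg, which is a limit and not a number. Taking 1-carboxyethyl in place of 1-carboxy-1-methylethyl at this position gives an at least 1.4-fold lower number from compound 3 to compound 4 (0.16 log units; that floor lies within the scatter), so the floor of this step does not clear the scatter, and the true size of the step stays unknown. The clearer reading comes from the drawn stereocentre, which the earlier compounds did not probe: an at least 2.3-fold lower number from compound 1 to compound 4 (0.36 log units; beyond the scatter), and that step is tied to the configuration at the saturated chain carbon, drawn as S in one compound and without a configuration in the other, and not to any change in atoms or bonds: the fact that one of compounds 1 and 4 is drawn with a defined configuration and the other without, at the place where they differ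

On these data alone, the step between compound 2 and compound 4 cannot be read, and neither compound can be ranked against the other: the limit of < 15 mL/min/kg in this assay, at which 2 of the 4 values shown sit. Still open is how the opposite configuration at this carbon would read in this assay, and how a longer chain, or an amide in place of the carboxylic acid, would behave at this position.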